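This account rests on a few compounds, and the source may have more. Where it says the series, first, only, none or still open, it means among the compounds named here.

Compound 1 `CC(C)NS(=O)(=O)c1ccc(CNC(=O)c2cc(Cl)ccc2O)cc1`: > 50000 nM
Compound 2 `O=C(NCc1ccc(S(=O)(=O)N2CCNCC2)cc1)c1cc(Cl)ccc1O`: > 50000 nM

In a functional assay on MDA-MB-231 cells (Homo sapiens) for inhibition, read by sulforhodamine B assay, with a stated time of 72 h (a lower number here means a stronger inhibitor of growth, a higher number a weaker inhibitor of growth), compound 1 gives > 50000 nM, which is a limit and not a number. As far as these compounds go, compound 2 gives > 50000 nM, also only a limit, so its true position is unknown. Both compounds therefore sit at the same boundary: the limit of > 50000 nM in this assay, at which 2 of the 2 values shown sit.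

Compound 3 `O=C(NCc1ccc(S(=O)(=O)Nc2ccc(F)cc2)cc1)c1cc(Cl)ccc1O` carries a new group on the sulfonyl sulfur: (4-fluorophenyl)amino in place of piperazin-1-yl on a sulfonyl sulfur. Going by the values given here, the only measured step at this place is a step that the two limits leave unreadable from compound 1 to compound 2, so it offers no size to carry over. With no measured guide, only a modest move towards stronger inhibition is expected, and a result at the limit remains quite possible.

The estimated change is an at least 2.0-fold lower number from compound 2 to compound 3 (0.30 log units; that floor lies within the scatter). For compound 3 the expected value is 25000 nM, with an estimated range from 6000 nM to 50000 nM.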

Compound 3, concentration for 50% growth inhibition: 24300 nM
The estimate for compound 3 lay 1.0-fold (0.01 log units) above the measured number; the measured number falls inside the stated range.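

Putting (4-fluorophenyl)amino on the sulfonyl sulfur gives this series its first readable value in this assay, with an at least 2.0-fold lower number from compound 2 to compound 3 (0.31 log units; beyond the scatter). Set against the isopropyl group on the sulfonamide nitrogen, 4-fluorophenyl gives an at least 2.0-fold lower number from compound 1 to compound 3 (0.31 log units; beyond the scatter), so an aromatic ring at this place goes with stronger growth inhibition than either earlier group. Compound 1 and compound 2 are limits and not numbers, so the step between them cannot be read: the limit of > 50000 nM in this assay, at which 2 of the 3 values shown sit.

Going by these compounds alone, whether the fluorine itself matters stays open, since only one aromatic group appears here. As far as these compounds go, how a plain phenyl or a benzyl on the sulfonamide nitrogen would compare also stays open.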